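The source may report more compounds than this note shows. Statements on the series, on what has been measured and on what is new or still open speak of the compounds shown alone.

Working notes on the series. In a functional assay on HEK293 cells for agonist activity at D(4) dopamine receptor (Homo sapiens), read by FLIPR (on this read-out higher numbers stand for an effect only at larger amounts of compound and lower numbers for an effect already at smaller amounts), compound 1 `Cc1cc(C(=O)NCN2CCC(c3cccc[n+]3[O-])CC2)ccc1F` gives 50 nM, which places it second highest of the three numbers to hand. Compound 3 `Cc1cccc(NC(=O)CN2CCC(c3cccc(O)c3)CC2)c1` gives 8 nM in this assay, and compound 2 `COc1cccc(C)c1NC(=O)CN1CCC(c2cccc[n+]2[O-])CC1` gives 340 nM; against both, compound 1 stands apart by more than the scatter, with a lower number for compound 3 and a higher one for compound 2. Within the data shown here, no pair of these three differs in only one place, so no single-point step can be read from them.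

Compound 4 `Cc1cc(C)cc(C(=O)NCN2CCC(c3cccc[n+]3[O-])CC2)c1` has not yet been measured in this assay. It differs from compound 1 in one place: 3,5-dimethylphenyl in place of 4-fluoro-3-methylphenyl on a carbonyl carbon. The change exchanges one substituent on the aromatic ring for another of the same size and the same count of donors and acceptors, and nothing measured here tells how such an exchange moves the number. The step from compound 1 to compound 4 is therefore expected to be small, a 1.3-fold lower number from compound 1 to compound 4 (0.10 log units; within the scatter), and not clearly beyond the scatter in either direction. For compound 4 the estimate in this assay is 40 nM, within a range from 15 nM to 120 nM.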

Compound 4, half-maximal effective concentration: 90 nM
Beside the measured number, compound 4's estimate is 2.3-fold (0.35 log units) below it; the measured number falls inside the stated range.
By their numbers in this assay, from the lowest: compound 3; then compounds 1 and 4 (each within the scatter of the next); then compound 2.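

Among these compounds, this is the first single-place step: at the position on a carbonyl carbon whose other neighbour is the amide-type nitrogen, 3,5-dimethylphenyl in place of 4-fluoro-3-methylphenyl gives a 1.8-fold higher number from compound 1 to compound 4 (0.26 log units; within the scatter) in this assay. On the core of compound 1, this exchange of one aromatic group for another with the same heavy-atom, donor and acceptor counts therefore leaves the number within the scatter. No measurement at hand bears on the cause of this result.

On these data alone, whether the position accepts groups of another kind, such as a carboxylic acid, an amine or a longer alkyl chain, remains open. The steps that would link compound 2 or compound 3 to compound 1 or compound 4 cannot be read, as each of these pairs differs in more than one place.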